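Sulfonamide nitrogen substituent in the shared core series

The compounds below may be only part of what the source reports. "The series", "measured", "known", "first", "only" and "open" are said of these compounds alone.

Compound 3 `CC(C)c1noc(N2CCN(C(=O)[C@@H]3CCCN(S(=O)(=O)c4ccc(S(=O)(=O)NC5CCC5)cc4)C3)CC2)n1` carries a cyclobutyl group on the sulfonamide nitrogen. In a functional assay on MIA PaCa-2 cells (Homo sapiens) for inhibition, read by MTT assay, with a stated time of 3 days (on this read-out higher numbers stand for weaker inhibition and lower numbers for stronger inhibition), compound 3 gives only a limit, > 10000 nM. Compound 1 `CC(C)c1noc(N2CCN(C(=O)[C@@H]3CCCN(S(=O)(=O)c4ccc(S(=O)(=O)NC5CC5)cc4)C3)CC2)n1`, with cyclopropyl in that place, likewise reaches only a limit in this assay, > 10000 nM. Compound 2 `CC(C)c1noc(N2CCN(C(=O)[C@@H]3CCCN(S(=O)(=O)c4ccc(S(=O)(=O)C(C)C)cc4)C3)CC2)n1`, with isopropyl on the sulfonyl sulfur, gives a limit too in this assay, > 10000 nM. The steps among these three, a step that the two limits leave unreadable from compound 1 to compound 3, a step that the two limits leave unreadable from compound 1 to compound 2 and a step that the two limits leave unreadable from compound 2 to compound 3, cannot be read as to size or direction because every value sits at the limit of > 10000 nM in this assay, at which 3 of the 3 values shown sit.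

Compound 4 `CCNS(=O)(=O)c1ccc(S(=O)(=O)N2CCC[C@@H](C(=O)N3CCN(c4nc(C(C)C)no4)CC3)C2)cc1` differs from compound 3 in one place: ethyl in place of cyclobutyl on a sulfonamide nitrogen. The measured steps that bear on this change are the two that alter the same sulfonamide substituent, and both are unreadable, so they set no direction. Since all three measured compounds rest at the limit of > 10000 nM in this assay, at which 3 of the 3 values shown sit, compound 4 is expected to stay at or near that limit in this assay, with a step that the limit leaves unreadable from compound 3 to compound 4 understood as no readable step. Compound 4 is estimated at 20000 nM, within 5000 nM to 80000 nM.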

Compound 4, half-maximal inhibitory concentration: > 10000 nM
Compound 4 gave a limit, no number; the forecaster's own chance of this, stated with the estimate: 85%; the middle value is on the limit's open side.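

Compound 4 gives only a limit of > 10000 nM and no new step can be read among compound 1, compound 2, compound 3 and compound 4: the limit of > 10000 nM in this assay, at which 4 of the 4 values shown sit. The compounds shown leave open whether any group on the sulfonyl sulfur gives a measurable value in this assay for this series.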